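The compounds below may be only part of what the source reports. "The series", "measured", "known", "first", "only" and "open" are said of these compounds alone.

Compound 1 `Oc1cccc(-c2cc(-c3cccs3)cc(-c3ccccc3O)n2)c1` carries a 3-hydroxyphenyl group that is exchanged for a 4-hydroxyphenyl group in compound 2 `Oc1ccc(-c2cc(-c3cccs3)cc(-c3ccccc3O)n2)cc1` (4-hydroxyphenyl in place of 3-hydroxyphenyl on an aromatic carbon). In a functional assay on HeLa cells (Homo sapiens) for cytotoxicity, read by CCK-8 assay (a lower number here means a stronger inhibitor, a higher number a weaker inhibitor), compound 1 gives > 50000 nM, which is a limit of the assay and not a number. Compound 2 gives > 50000 nM in this assay, again a limit rather than a number. The step that the two limits leave unreadable from compound 1 to compound 2 therefore cannot be read, and the limit of > 50000 nM in this assay, at which 2 of the 3 values shown sit, is where both of these values sit. Compound 3 `Oc1cccc(-c2cc(-c3ccccn3)cc(-c3cccc(O)c3)n2)c1` rests on another core; the difference between the two cores is not broken down here. In this assay compound 3 gives 6500 nM. Compound 4 `Oc1ccc(-c2cc(-c3ccccn3)cc(-c3cccc(O)c3)n2)cc1` arises from compound 3 by the same kind of change (4-hydroxyphenyl in place of 3-hydroxyphenyl on an aromatic carbon); around the place the surroundings differ, the new group standing meta to a 3-hydroxyphenyl group and meta to a pyridin-2-yl group rather than meta to a 2-hydroxyphenyl group and meta to a thiophen-2-yl group. The step that the two limits leave unreadable from compound 1 to compound 2 gives no readable size, so only a small step of a 1.2-fold higher number from compound 3 to compound 4 (0.09 log units; within the scatter) is expected, resting on the value of compound 3 6500 nM. Compound 4 is estimated at 8000 nM, expected between 2500 nM and 30000 nM.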

Compound 4, half-maximal inhibitory concentration: 1930 nM
Beside the measured number, compound 4's estimate is 4.1-fold (0.62 log units) above it; the measured number lies below the stated range.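

On the core of compound 3, the exchange of 3-hydroxyphenyl for 4-hydroxyphenyl gives a 3.4-fold lower number from compound 3 to compound 4 (0.53 log units; beyond the scatter) in this assay, so here the change has a readable effect on the number. The same exchange on the core of compound 1 cannot be read, as compound 1 and compound 2 both stand at a limit of the assay and not at numbers: the limit of > 50000 nM in this assay, at which 2 of the 4 values shown sit. The series therefore offers a single readable case, which does not show whether the size or even the direction of the step carries from one core to the other.

The compounds shown leave open whether the hydroxyl itself matters on the core of compound 3, as an amine, a methoxy group or a carboxylic acid in its place on that ring does not appear among them. They also leave open which of the differences between the two cores governs the numbers, as compound 1 and compound 3 differ in more than one place.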